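The source may report more compounds than this note shows. Statements on the series, on what has been measured and on what is new or still open speak of the compounds shown alone.

Measured so far:
compound 1, `CNC(=O)c1cccc(Cn2nc(C)c(NC(=O)c3ccc(COc4cccc(C)c4)cc3)c2C)c1`: 6200 nM
compound 2, `CNC(=O)c1cccc(Cn2nc(C)c(NC(=O)c3ccc(COc4ccc(OC)cc4)cc3)c2C)c1`: 8000 nM

Both numbers come from a functional assay on MIA PaCa-2 cells (Homo sapiens) for antiproliferative activity, read by MTT assay, with a stated time of 72 h; on this read-out higher numbers stand for an effect only at larger amounts of compound and lower numbers for an effect already at smaller amounts. Compound 2 carries the higher of the two numbers, but the gap to compound 1 is small: a 1.3-fold higher number from compound 1 to compound 2 (0.11 log units; within the scatter). The two compounds therefore cannot be ordered against each other on this assay.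

The next compound to be measured is compound 3, `CNC(=O)c1cccc(Cn2nc(C)c(NC(=O)c3ccc(COc4ccc(Cl)cc4)cc3)c2C)c1`. It differs from compound 2 in one place: chloro in place of methoxy on an aromatic carbon. For the measured compounds named here, the only measured step that speaks to this part of the structure is the one that swapped the phenyl on the oxygen on a saturated carbon between compound 1 and compound 2, which gave a 1.3-fold higher number from compound 1 to compound 2 (0.11 log units; within the scatter). Within those two compounds, exchanging one substituted phenyl for another moved the number little; no compound carrying chloro is available to check this exchange directly. A step of about the same small size is expected here, a 1.3-fold lower number from compound 2 to compound 3 (0.12 log units; within the scatter), with no clear direction beyond the scatter. Compound 3 is therefore estimated at 6000 nM, with a range from 2500 nM to 14000 nM in this assay.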

Compound 3, half-maximal effective concentration: 4200 nM
Compound 3: the middle estimate sits 1.4-fold (0.15 log units) above what was measured; measured number inside the range.
By their numbers in this assay, from the lowest: compounds 3, 1 and 2 (each within the scatter of the next).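

In this assay, chloro in place of methoxy on the aromatic carbon para to a large group gives a 1.9-fold lower number from compound 2 to compound 3 (0.28 log units; within the scatter), so this first change away from an oxygen-linked substituent at this position does not move the number beyond the scatter. Exchanging the whole aryl group, with 4-chlorophenyl in place of 3-methylphenyl on the oxygen, gives a 1.5-fold lower number from compound 1 to compound 3 (0.17 log units; within the scatter), so compound 1, compound 2 and compound 3 remain one group that cannot be ordered in this assay, and no substitution shown on this phenyl separates from the others. Nothing is available that would account for these numbers.

Still open, on these data alone, is whether any change on this phenyl can move the number beyond the scatter, for example an amine or a carboxylic acid in place of chloro, or a plain unsubstituted phenyl on the oxygen. The compounds shown also share the core and the methylamide unchanged, so they give no reading of how the number responds to changes anywhere else in the molecule.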